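Series notes: fluoro on the methylpyridinyl ether

The compounds below may be only part of what the source reports. "The series", "measured", "known", "first", "only" and "open" are said of these compounds alone.

Compound 2 `Cc1cccnc1Oc1ccc2nc(COc3cccc(C(=O)O)c3)n(C)c2c1` gives 6 10^-6 cm/s in an ADME assay for permeability, using PAMPA, with a stated time of 4 h (a higher number here means that the compound crosses the layer faster, a lower number that the compound crosses the layer more slowly), the highest of the two numbers measured. Compound 1 `Cc1cccc(Oc2ccc3nc(COc4cccc(C(=O)O)c4)n(C)c3c2)n1` gives 2.7 10^-6 cm/s in this assay. Among the compounds with values here, the one measured step is a 2.2-fold higher number from compound 1 to compound 2 (0.35 log units; beyond the scatter). Compound 3 `Cc1cc(F)cnc1Oc1ccc2nc(COc3cccc(C(=O)O)c3)n(C)c2c1` differs from compound 2 by fluoro in place of hydrogen on an aromatic carbon. Within the data shown here, no measured step covers fluoro in place of hydrogen, so the single step measured does not bear directly on this change. A step of at most modest size in this assay is expected, with no direction established. Compound 3 is estimated at 7 10^-6 cm/s with a range of 3.5 10^-6 cm/s to 14 10^-6 cm/s. The expected step is a 1.2-fold higher number from compound 2 to compound 3 (0.07 log units; within the scatter).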

Compound 3, apparent permeability: 8.3 10^-6 cm/s
The estimate for compound 3 lay 1.2-fold (0.07 log units) below the measured number; measured number inside the range.
By their numbers in this assay, from the lowest: compound 1; then compounds 2 and 3 (each within the scatter of the next).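

Fluoro on the pyridine carbon para to a large group gives a 1.4-fold higher number from compound 2 to compound 3 (0.14 log units; within the scatter) in this assay, so this first hydrogen-to-fluoro step leaves the number within the scatter of compound 2. Replacing 6-methylpyridin-2-yl with 5-fluoro-3-methylpyridin-2-yl gives a 3.1-fold higher number from compound 1 to compound 3 (0.49 log units; beyond the scatter) in this comparison, and compound 3 stays clearly separated from compound 1. Nothing here explains either step.

As far as these compounds go, whether chloro or methoxy at this same position would depart from hydrogen remains open. So does whether fluoro gives a similar step with the 6-methylpyridin-2-yl ether of compound 1.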